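Glucagon receptor binders: trifluoromethoxy for trifluoromethyl

The source may hold more compounds than are shown below. What is called first, only, known or untested is meant among the compounds shown, and "the series" means these compounds.

Measured so far:
- compound 1 `O=C(O)CCNC(=O)c1ccc(CN(c2ccc(C3=CCCCC3)cc2)c2nc(-c3ccc(Cl)cc3)c(-c3ccccc3)s2)cc1`: 86 nM
- compound 2 `O=C(O)CCNC(=O)c1ccc(CC(c2ccc(Cl)cc2)c2nc(-c3ccc(C(F)(F)F)cc3)cs2)cc1`: 96 nM

In an in vitro assay on BHK cells for displacement of a labelled ligand from Glucagon receptor (Homo sapiens), read by scintillation proximity assay (a higher number here means a weaker inhibitor, a lower number a stronger inhibitor), compound 1 gives 86 nM and compound 2 gives 96 nM. Compound 2 has the highest of the two numbers, but its nearest neighbour, compound 1, sits within the scatter of it, so the two read as equivalent and nothing can be said of their order. For the measured compounds named here, no pair of measured compounds differs in a single place, so no step size has been measured yet.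

Compound 3 `O=C(O)CCNC(=O)c1ccc(CC(c2ccc(Cl)cc2)c2nc(-c3ccc(OC(F)(F)F)cc3)cs2)cc1` is the next compound for this assay. It differs from compound 2 in one place: trifluoromethoxy in place of trifluoromethyl on an aromatic carbon. The change sits on an aromatic carbon of a six-membered aromatic ring of carbon only, para to a large group; one heavy atom and one hydrogen-bond acceptor enter, nothing else changes. Going by the values given here, no measured step bears on this exchange. The step of a 1.1-fold lower number from compound 2 to compound 3 (0.03 log units; within the scatter) is expected to be none beyond the scatter. Compound 3 is estimated at 90 nM, with a range from 40 nM to 220 nM.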

Compound 3, half-maximal inhibitory concentration: 153 nM
Compound 3: middle estimate off by 1.7-fold (0.23 log units), on the low side; low and high end bracket the measured number.
By their numbers in this assay, from the lowest: compounds 1, 2 and 3 (each within the scatter of the next).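

Trifluoromethoxy in place of trifluoromethyl is the first single-place exchange read in this series: in this assay it gives a 1.6-fold higher number from compound 2 to compound 3 (0.20 log units; within the scatter). At this place, on an aromatic carbon para to a large group, the entry of one oxygen and one hydrogen-bond acceptor therefore does not separate the two compounds, and the two groups read as equivalent. No available evidence speaks to the basis of this result.

Going by these compounds, whether a methoxy, a nitrile, a chlorine or an amine at the same place would give a number beyond the scatter of these two groups remains open. Also open, on these data alone, is whether the same exchange would read alike with a different group in place of the chlorophenyl on the shared core.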